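Methyl for Hydroxy on the Aryl Ring of Compound 2

This account rests on a few compounds, and the source may have more. Where it says the series, first, only, none or still open, it means among the compounds named here.

Measured compounds:
compound 1 `C[C@H]1CC[C@@H]2[C@@H](OC(=O)[C@]23CC(c2ccc(N(C)C)cc2)=NO3)[C@]2(C)C(=O)C=C[C@@]12O` — 5100 nM
compound 2 `C[C@H]1CC[C@@H]2[C@@H](OC(=O)[C@]23CC(c2ccc(O)cc2)=NO3)[C@]2(C)C(=O)C=C[C@@]12O` — 89000 nM

In a functional assay on SW-620 cells (Homo sapiens) for cytotoxicity, read by sulforhodamine B assay, with a stated time of 48 h (a higher number here means a weaker inhibitor, a lower number a stronger inhibitor), compound 2 gives 89000 nM, the highest of the two numbers; its nearest neighbour is compound 1, and the step of a 17-fold higher number from compound 1 to compound 2 (1.24 log units; beyond the scatter) shows that the group on this aromatic carbon moves the result a great deal. Compound 3 `Cc1ccc(C2=NO[C@]3(C2)C(=O)O[C@@H]2[C@H]3CC[C@H](C)[C@]3(O)C=CC(=O)[C@@]23C)cc1` has not been measured; it differs from compound 2 by methyl in place of hydroxy on an aromatic carbon. Among the measured compounds shown here, no measured step covers a methyl at this position, so the direction is uncertain. For the measured compounds named here, the only related step, a 17-fold higher number from compound 1 to compound 2 (1.24 log units; beyond the scatter), shows a large spread between two groups on this carbon, so a step beyond the scatter in either direction is possible for compound 3. With compound 1 at 5100 nM and compound 2 at 89000 nM framing the known range, compound 3 is expected to fall between them, at 25000 nM (range 6000 nM to 90000 nM), an expected step of a 3.6-fold lower number from compound 2 to compound 3 (0.55 log units; beyond the scatter).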

Compound 3, half-maximal inhibitory concentration: 2500 nM
Compound 3: middle estimate off by 10-fold (1.00 log units), on the high side; measured number below the stated range.
By their numbers in this assay, from the lowest: compound 3; then compound 1; then compound 2.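

In this assay, methyl in place of hydroxy gives a 36-fold lower number from compound 2 to compound 3 (1.55 log units; beyond the scatter), which shows that this aromatic carbon can carry a plain carbon group and still give the lowest number of the three compounds. Methyl in place of dimethylamino gives a 2.0-fold lower number from compound 1 to compound 3 (0.31 log units; beyond the scatter), a modest step, so a low number at this position does not depend on the dimethylamino group, and of the three groups it is hydroxy that stands apart with the high number. Nothing available explains why these groups differ so much at this position.

Among the compounds shown here, with only three groups at this carbon, no ordering can be extended to other substituents. A methoxy group, a chlorine atom, a longer chain such as ethyl or a primary amine at this position would test whether the low numbers hold beyond methyl and dimethylamino.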